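Fluoro on the Phenyl of Compound 3

A few compounds are considered here, and "the series" means these few. Any claim that something is new, unique, unknown or untested is made for them only; others in the source may bear on it.

In a functional assay on THP-1 cells (Homo sapiens) for inhibition, read by ELISA, with stated times of 1 h and 18 h (a lower number here means a stronger inhibitor, a higher number a weaker inhibitor), compound 1 `Cc1cnc(Nc2cccc(C(=O)N3CCCC3)c2)nc1N[C@H]1[C@@H](C(N)=O)[C@@H]2C=C[C@H]1C2` gives 100 nM and compound 2 `NC(=O)[C@@H]1[C@H](Nc2nc(Nc3cccc(C(=O)N4CCCC4)c3)ncc2-c2ccsc2)[C@H]2C=C[C@@H]1C2` gives 110 nM while compound 3 `NC(=O)[C@@H]1[C@H](Nc2nc(Nc3cccc(C(=O)N4CCCC4)c3)ncc2-c2ccccc2)[C@H]2C=C[C@@H]1C2` gives 220 nM on the shared core. Compound 3 thus stands close to one neighbour and apart from the other, with a 2.0-fold higher number from compound 2 to compound 3 (0.30 log units; within the scatter) and a 2.2-fold higher number from compound 1 to compound 3 (0.34 log units; beyond the scatter) as its two steps. Compound 4 `NC(=O)[C@@H]1[C@H](Nc2nc(Nc3cccc(C(=O)N4CCCC4)c3)ncc2-c2ccccc2F)[C@H]2C=C[C@@H]1C2` follows from compound 3 through fluoro in place of hydrogen on an aromatic carbon and so carries 2-fluorophenyl in place of phenyl. For the measured compounds named here, no measured step adds a fluoro. The nearest evidence is swaps of groups on an aromatic carbon, which gave a 1.1-fold higher number from compound 1 to compound 2 (0.04 log units; within the scatter) and the two steps above, none more than modest. In this assay no step beyond the scatter is expected, and the estimate is a 1.1-fold lower number from compound 3 to compound 4 (0.04 log units; within the scatter) in size. For compound 4 the estimated value is 200 nM (expected range 90 nM to 450 nM).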

Compound 4, half-maximal inhibitory concentration: 130 nM
Beside the measured number, compound 4's estimate is 1.5-fold (0.19 log units) above it; low and high end bracket the measured number.
By their numbers in this assay, from the lowest: compounds 1, 2, 4 and 3 (each within the scatter of the next, the first and the last beyond it).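

In this assay the phenyl of compound 3 takes a fluoro on an aromatic carbon ortho to a large group without a readable change, as a 1.7-fold lower number from compound 3 to compound 4 (0.23 log units; within the scatter) shows. With a 1.2-fold higher number from compound 2 to compound 4 (0.07 log units; within the scatter) and a 1.3-fold higher number from compound 1 to compound 4 (0.11 log units; within the scatter), 2-fluorophenyl also falls within the scatter of both thiophen-3-yl and methyl, whereas phenyl lay just beyond it from methyl. No measurement shown bears on why this is so. The compounds shown leave open whether fluoro reads the same elsewhere on the phenyl, and whether methoxy or an amine would hold the number in this place.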